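Swapping the aryl group on the core: compound 3 to compound 4

The source may report more compounds than this note shows. Statements on the series, on what has been measured and on what is new or still open speak of the compounds shown alone.

Three compounds share one core and were tested in an assay on LM cells for displacement of a labelled ligand from Neuropeptide Y receptor type 5 (Homo sapiens); on this read-out higher numbers stand for weaker inhibition and lower numbers for stronger inhibition. Compound 1 `Fc1ccc(C2(c3ccc(F)cc3)CNC(c3cccc(Cl)c3)=N2)cc1` gives 5.4 nM, compound 2 `Fc1ccc(C2(c3ccc(F)cc3)CNC(c3ccc(C(F)(F)F)cc3)=N2)cc1` gives 160 nM, and compound 3 `OCc1cccc(C2=NC(c3ccc(F)cc3)(c3ccc(F)cc3)CN2)c1` gives 59 nM. Among the measured compounds shown here, compound 3 thus holds the second highest of the three numbers; its value sits closest to that of compound 2 and farthest from that of compound 1, and the only single change recorded, an 11-fold higher number from compound 1 to compound 3 (1.04 log units; beyond the scatter), was large. Compound 4 `Fc1ccc(C2(c3ccc(F)cc3)CNC(c3cncnc3)=N2)cc1` carries the change (pyrimidin-5-yl in place of 3-(hydroxymethyl)phenyl on a carbon with a double bond to nitrogen). For the measured compounds named here, no recorded step replaces this aryl group with a heteroaromatic ring, so the direction rests on the fact that altering the group on this carbon has so far shifted this assay strongly. Compound 4 is therefore expected to move by a 2.5-fold higher number from compound 3 to compound 4 (0.41 log units; beyond the scatter), giving an estimated 150 nM with a range from 30 nM to 800 nM.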

Compound 4, half-maximal inhibitory concentration: 47 nM
Compound 4: the middle estimate sits 3.2-fold (0.50 log units) above what was measured; the measured number falls inside the stated range.
By their numbers in this assay, from the lowest: compound 1; then compounds 4 and 3 (each within the scatter of the next); then compound 2.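

In this assay, two very different rings on this carbon read alike, with a 1.3-fold lower number from compound 3 to compound 4 (0.10 log units; within the scatter), so this position tolerates pyrimidin-5-yl as well as 3-(hydroxymethyl)phenyl and does not depend on the hydroxymethyl group. Neither ring matches 3-chlorophenyl, since pyrimidin-5-yl gives an 8.7-fold higher number from compound 1 to compound 4 (0.94 log units; beyond the scatter), a clear loss against the chloro compound. Nothing measured here explains why these two rings read alike. On these data alone, it remains open whether a pyridin-3-yl ring or a 3-aminophenyl group on this carbon would come closer to compound 1.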